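Swapping the Thiophene for a Pyridine

A few compounds are considered here, and "the series" means these few. Any claim that something is new, unique, unknown or untested is made for them only; others in the source may bear on it.

Going by the values given here, compound 2 `CC(Oc1ccccc1-c1cccs1)C1=NCCN1` stands at the better end of the two numbers so far: in an assay on CHO cells for displacement of a labelled ligand from Alpha-2C adrenergic receptor (Homo sapiens) (on this read-out lower numbers stand for stronger inhibition and higher numbers for weaker inhibition), compound 2 gives 72.4 nM, while compound 1 `Cc1ccc(-c2ccccc2OC(C)C2=NCCN2)cc1` gives 251 nM. Among the compounds with values here, the one measured step that joins them is a 3.5-fold lower number from compound 1 to compound 2 (0.54 log units; beyond the scatter), a change that replaced a carbon-only ring with a five-membered aromatic ring bearing one hetero atom.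

Compound 3 `CC(Oc1ccccc1-c1ccccn1)C1=NCCN1` takes the next step from compound 2: pyridin-2-yl in place of thiophen-2-yl on an aromatic carbon. Within the data shown here, no measured pair shows what a pyridin-2-yl does in this position, so the only guide is the step from compound 1 to compound 2, which shows that the identity of the ring at this position moves this assay by a modest amount. Both rings entering and leaving here carry one hetero atom and one hydrogen-bond acceptor, so a step of that size in either direction, or none beyond the scatter, would fit what is known.

Compound 3 is therefore expected to stay near compound 2, with an estimated step of a 1.5-fold higher number from compound 2 to compound 3 (0.18 log units; within the scatter), giving an expected value of 110 nM, with a range from 35 nM to 350 nM.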

Compound 3, inhibition constant: 1260 nM
For compound 3 the middle estimate is 11-fold (1.06 log units) below the measured one; the measured number lies above the stated range.
By their numbers in this assay, from the lowest: compound 2; then compound 1; then compound 3.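

In this assay this position proves more sensitive than the first step suggested, since a 17-fold higher number from compound 2 to compound 3 (1.24 log units; beyond the scatter) is clearly larger than a 3.5-fold lower number from compound 1 to compound 2 (0.54 log units; beyond the scatter), and compound 3 is the weakest of the three. Thiophen-2-yl and pyridin-2-yl each carry one hetero atom and one hydrogen-bond acceptor, yet these shared counts did not keep the two compounds close, and a 5.0-fold higher number from compound 1 to compound 3 (0.70 log units; beyond the scatter) places the carbon-only 4-methylphenyl ring between the two hetero-atom rings, so the presence of a hetero atom in the ring does not by itself set the order among these compounds. Nothing available gives a reason for the large change seen with pyridin-2-yl.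

The compounds shown leave open whether pyridin-3-yl or pyridin-4-yl would behave like pyridin-2-yl, and whether furan-2-yl, with oxygen in place of the sulfur of thiophen-2-yl, would stay near compound 2. They also leave open how an unsubstituted phenyl would compare, which matters for reading the step from 4-methylphenyl to pyridin-2-yl, as that step changes both the ring atoms and the methyl group.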